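Series notes: ring-nitrogen substitution on the shared core

A few compounds are considered here, and "the series" means these few. Any claim that something is new, unique, unknown or untested is made for them only; others in the source may bear on it.

Compound 1 `CN1CCN(c2ccc(C3=NNC(c4ccc(N(C)C)cc4)C3)cc2)CC1` carries a hydrogen on the ring nitrogen of the shared core. In a functional assay on HCC1806 cells (Homo sapiens) for inhibition, read by sulforhodamine B assay, tested at 10 uM (a lower number here means less inhibition, a higher number more inhibition at the concentration tested (going by the name of the read-out)), compound 1 gives 31.2%, the lowest of the three numbers measured. Compound 2 `CN1CCN(c2ccc(C3=NN(C(=O)c4ccc(F)cc4)C(c4ccc(N(C)C)cc4)C3)cc2)CC1` gives 31.8%, and compound 3 `CN1CCN(c2ccc(C3=NN(C(=O)/C=C/c4ccccc4)C(c4ccc(N(C)C)cc4)C3)cc2)CC1` gives 71%.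

Two steps replace that hydrogen. The step of a number 0.6 percentage points higher from compound 1 to compound 2 (within the scatter) lies within the scatter, whereas the step of a number 39.8 percentage points higher from compound 1 to compound 3 (beyond the scatter) is large; the step of a number 39.2 percentage points higher from compound 2 to compound 3 (beyond the scatter) shows the same gap between the two substituents.

Compound 4 `CN1CCN(c2ccc(C3=NN(S(=O)(=O)c4ccc(Br)cc4)C(c4ccc(N(C)C)cc4)C3)cc2)CC1` is not yet measured. The change from compound 1 is (4-bromophenyl)sulfonyl in place of hydrogen on an amine nitrogen in a ring. Both measured steps bear on it, since both put a group on the same nitrogen. An aromatic ring attached directly to the attaching atom, as in compound 2, left the number unchanged within the scatter, while the large rise belongs only to compound 3. Compound 4 resembles compound 2 more closely, so in this assay a step of about a number 4.8 percentage points higher from compound 1 to compound 4 (within the scatter) is expected, not beyond the scatter. Compound 4 is therefore estimated at 36%, in the range 18% to 62%.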

Compound 4, a percentage reported as inhibition, at one concentration (the size of the read-out at that concentration, not a potency): 87.1%
The estimate for compound 4 lay 51.1 percentage points below the measured number; measured number above the stated range.
By their numbers in this assay, from the lowest: compounds 1 and 2 (each within the scatter of the next); then compound 3; then compound 4.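

The nitrogen of the shared core can carry an aromatic ring directly on the attaching atom without the number staying flat: in this assay the step of a number 55.9 percentage points higher from compound 1 to compound 4 (beyond the scatter) is large, so the large rise no longer belongs to compound 3 alone. The step of a number 55.3 percentage points higher from compound 2 to compound 4 (beyond the scatter) joins two groups that each hold one aromatic ring, while the modest step of a number 16.1 percentage points higher from compound 3 to compound 4 (beyond the scatter) shows that the (4-bromophenyl)sulfonyl group also stands beyond the scatter of the (2-phenylethenyl)carbonyl group. No measurement at hand accounts for these differences.

Going by these compounds, compound 2 and compound 4 differ in both the linking group and the halogen, so the share of each stays open. A plain phenylsulfonyl group, a 4-fluorophenylsulfonyl group or a methylsulfonyl group would begin to separate them.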